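Amide-bearing aryl substituents in the shared core series

A few compounds are considered here, and "the series" means these few. Any claim that something is new, unique, unknown or untested is made for them only; others in the source may bear on it.

Going by the values given here, compound 2 `Cn1nc2c(=O)n(CC3(O)CCN(Cc4ccc(-c5ccco5)cc4Cl)CC3)cnc2c1-c1ccc(OC(F)F)cc1` gives 179 nM in an assay on isolated protein for inhibition of ubiquitin carboxyl-terminal hydrolase 7 (Homo sapiens), with stated times of 30 min and 2 h (a lower number here means a stronger inhibitor, a higher number a weaker inhibitor), the higher of the two numbers so far, while compound 1 `Cn1nc2c(=O)n(CC3(O)CCN(Cc4ccc(-c5ccco5)cc4Cl)CC3)cnc2c1-c1ccc(CNC=O)cc1` gives 20.9 nM. Compound 3 `CC(=O)NCc1ccc(-c2c3ncn(CC4(O)CCN(Cc5ccc(-c6ccco6)cc5Cl)CC4)c(=O)c3nn2C)cc1` differs from compound 2 by acetamidomethyl in place of difluoromethoxy on an aromatic carbon, on an aromatic carbon of a six-membered aromatic ring of carbon only, para to a large group. Among the compounds with values here, the one step that bears on this is an 8.6-fold higher number from compound 1 to compound 2 (0.93 log units; beyond the scatter), which runs the opposite way for the (formylamino)methyl group. Acetamidomethyl is expected to recover most of that ground, so compound 3 is estimated at 30 nM (range 12 nM to 80 nM), a step of a 6.0-fold lower number from compound 2 to compound 3 (0.78 log units; beyond the scatter) toward the lower number.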

Compound 3, half-maximal inhibitory concentration: 46.1 nM
Compound 3: middle estimate off by 1.5-fold (0.19 log units), on the low side, and the stated range covers the measured number.
By their numbers in this assay, from the lowest: compound 1; then compound 3; then compound 2.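

Acetamidomethyl also gives a lower number than difluoromethoxy at this place on the ring, para to a large group, in this assay (a 3.9-fold lower number from compound 2 to compound 3 (0.59 log units; beyond the scatter)), so the gain over difluoromethoxy is not limited to the (formylamino)methyl group of compound 1. The acyl end of the chain still matters: methyl in place of hydrogen on the carbonyl carbon gives a higher number (a 2.2-fold higher number from compound 1 to compound 3 (0.34 log units; beyond the scatter)). Nothing available explains either step.

Open, on these data alone, is whether a longer acyl chain such as propionyl raises the number further, and how a free aminomethyl group or a carboxylic acid would compare at this place.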